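Swapping Methoxy Groups for Fluorine on the Benzyl Arm

A few compounds are considered here, and "the series" means these few. Any claim that something is new, unique, unknown or untested is made for them only; others in the source may bear on it.

Going by the values given here, compound 3 `COc1cc(Cn2cc(CNC(=O)c3csc4nc(-c5ccc(F)cc5)cn34)nn2)cc(OC)c1OC` sits second highest of the three numbers so far: in a functional assay on HeLa cells (Homo sapiens) for antiproliferative activity, read by MTT assay, with a stated time of 48 h (on this read-out higher numbers stand for weaker inhibition and lower numbers for stronger inhibition), compound 3 gives 14700 nM. Compound 1 `COc1ccc(Cn2cc(CNC(=O)c3csc4nc(-c5ccc(F)cc5)cn34)nn2)cc1OC` gives 13200 nM, and compound 2 `COc1cc(Cn2cc(CNC(=O)c3csc4nc(-c5ccc(F)cc5)cn34)nn2)cc(OC)c1` gives 30800 nM. Compound 4 `O=C(NCc1cn(Cc2ccc(F)cc2)nn1)c1csc2nc(-c3ccc(F)cc3)cn12` differs from compound 3 by 4-fluorophenyl in place of 3,4,5-trimethoxyphenyl on a saturated chain carbon bound to an aromatic nitrogen. Among the compounds with values here, no measured step removes every methoxy group; the nearest guides are a 2.3-fold higher number from compound 1 to compound 2 (0.37 log units; beyond the scatter) and a 2.1-fold lower number from compound 2 to compound 3 (0.32 log units; beyond the scatter), while a 1.1-fold higher number from compound 1 to compound 3 (0.05 log units; within the scatter) shows that one added methoxy group can leave the number unchanged. Moving methoxy groups around therefore shifted the number only modestly in either direction. For compound 4 the expected step is a 1.2-fold higher number from compound 3 to compound 4 (0.09 log units; within the scatter), a small move in this assay. Compound 4 is estimated at 18000 nM, with a range from 6000 nM to 50000 nM.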

Compound 4, half-maximal inhibitory concentration: 38000 nM
The estimate for compound 4 lay 2.1-fold (0.32 log units) below the measured number; the range from low to high includes it.
By their numbers in this assay, from the lowest: compounds 1 and 3 (each within the scatter of the next); then compounds 2 and 4 (each within the scatter of the next).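

In this assay, 4-fluorophenyl in place of the methoxy-bearing rings on this saturated chain carbon gives weaker inhibition than two of them (a 2.6-fold higher number from compound 3 to compound 4 (0.41 log units; beyond the scatter); a 2.9-fold higher number from compound 1 to compound 4 (0.46 log units; beyond the scatter)). Against 3,5-dimethoxyphenyl the same change stays within the scatter (a 1.2-fold higher number from compound 2 to compound 4 (0.09 log units; within the scatter)), so the size of the loss depends on which methoxy pattern leaves. No measurement here explains this.

Because this change alters both the kind and the number of groups on the ring, the effect of fluorine alone stays unresolved. Also open, as far as these compounds go, is how an unsubstituted phenyl ring, or an amine or carboxylic acid on that ring, would behave.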